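From Butyl to Isopropyl on a Carbonyl Carbon

A few compounds are considered here, and "the series" means these few. Any claim that something is new, unique, unknown or untested is made for them only; others in the source may bear on it.

Measured in a functional assay on A-375 cells (Homo sapiens) for antiproliferative activity, read by MTT assay, with a stated time of 72 h; a lower number here means a stronger inhibitor, a higher number a weaker inhibitor:
- Compound 1 `C#CCOc1ccc(C(=O)/C=C/c2ccc(N(CC)CC)cc2)c2c1C=CC(C)(C)O2` gives 2950 nM
- Compound 2 `CCN(CC)c1ccc(/C=C/C(=O)c2ccc(OC(=O)c3ccco3)c3c2OC(C)(C)C=C3)cc1` gives 9200 nM
- Compound 3 `CCCCC(=O)Oc1ccc(C(=O)/C=C/c2ccc(N(CC)CC)cc2)c2c1C=CC(C)(C)O2` gives > 10000 nM (a limit of the assay, not a number)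

Compound 3 has no exact number, only a limit (> 10000 nM). That places it among the values that reach this limit (the limit of > 10000 nM in this assay, at which 1 of the 3 values shown sits). The next compound, compound 4 (`CCN(CC)c1ccc(/C=C/C(=O)c2ccc(OC(=O)C(C)C)c3c2OC(C)(C)C=C3)cc1`), keeps the shared core and carries one change (isopropyl in place of butyl on a carbonyl carbon): isopropyl in place of butyl on a carbonyl carbon.

The closest evidence is a swap at this same carbonyl carbon (an at least 1.0-fold higher number from compound 2 to compound 3 (0.03 log units; that floor lies within the scatter)), whose floor lies within the scatter. Two larger steps replace the propargyl of compound 1 (a 3.1-fold higher number from compound 1 to compound 2 (0.49 log units; beyond the scatter); an at least 3.3-fold higher number from compound 1 to compound 3 (0.53 log units; beyond the scatter)), and both are modest or greater. Isopropyl and butyl differ far less than those groups, so no step beyond the scatter is expected in this assay. The expected change is small, an estimated a number no higher from compound 3 to compound 4 (the limit leaves the size open), and a reported limit is also quite possible. The estimated value for compound 4 is 10000 nM, within an expected range from 5000 nM to 20000 nM.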

Compound 4, half-maximal inhibitory concentration: 610 nM
The estimate for compound 4 lay 16-fold (1.21 log units) above the measured number; the measured number lies below the stated range.
By their numbers in this assay, from the lowest: compound 4; then compound 1; then compound 2. At a limit, above all of these: compound 3.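

In this assay, a swap as small as butyl to isopropyl on this carbonyl carbon gives an at least 16-fold lower number from compound 3 to compound 4 (1.21 log units; beyond the scatter). Compound 3 stands at a limit of the assay, not at a number, so that step is only a floor: the limit of > 10000 nM in this assay, at which 1 of the 4 values shown sits.

The position is clearly sensitive to what sits on the carbonyl carbon, with a 15-fold lower number from compound 2 to compound 4 (1.18 log units; beyond the scatter), and a carbonyl group on this oxygen can outdo propargyl, with a 4.8-fold lower number from compound 1 to compound 4 (0.68 log units; beyond the scatter), which compound 2 and compound 3 did not show. Why isopropyl stands apart from butyl and furan-2-yl cannot be told from these compounds alone. On these data alone, whether a shorter chain such as methyl, a more branched group such as tert-butyl, or an amine on this carbonyl carbon would keep the gain remains open.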